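Replacing the carboxy chain of compound 1

The source may hold more compounds than are shown below. What is called first, only, known or untested is meant among the compounds shown, and "the series" means these compounds.

In an ADME assay on the whole organism (strain CD-1) for metabolic stability, with Mus musculus as the target, at a dose of 3 mg/kg by the intravenous route (a lower number here means that the compound disappears faster, a higher number that the compound lasts longer), compound 1 `CN(Cc1ccccc1OCCCCC(C)(C)C(=O)O)C(=O)c1ccc(-c2ccco2)cc1` gives 4.6 h. Compound 2 `CN(Cc1ccccc1OCCC[C@@H]1C[C@H]1C(=O)O)C(=O)c1ccc(-c2ccco2)cc1` gives 3.5 h, which stands level with compound 1 within the scatter, as a 1.3-fold lower number from compound 1 to compound 2 (0.12 log units; within the scatter) shows. Compound 3 `C/C(=C\C(=O)O)CCCOc1ccccc1CN(C)C(=O)c1ccc(-c2ccco2)cc1` gives 1.6 h, the only clear separation, with a 2.9-fold lower number from compound 1 to compound 3 (0.46 log units; beyond the scatter) and a 2.2-fold lower number from compound 2 to compound 3 (0.34 log units; beyond the scatter). Compound 4 `CC(CCOc1ccccc1CN(C)C(=O)c1ccc(-c2ccco2)cc1)CCC(=O)O` has 3-carboxy-1-methylpropyl in place of 3-carboxy-3-methylbutyl, on a saturated chain carbon, two bonds along the chain from an oxygen on an aromatic ring: 3-carboxy-1-methylpropyl in place of 3-carboxy-3-methylbutyl on a saturated chain carbon, two bonds along the chain from an oxygen on an aromatic ring. The measured steps also replace the chain end of compound 1, and they run from within the scatter to modest. A modest downward move in this assay is therefore expected. The expected change is a 2.3-fold lower number from compound 1 to compound 4 (0.36 log units; beyond the scatter). For compound 4 the estimate is 2 h, with an expected range of 0.9 h to 4.2 h.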

Compound 4, half-life: 1.7 h
Compound 4: the middle estimate sits 1.2-fold (0.07 log units) above what was measured; the measured number falls inside the stated range.
By their numbers in this assay, from the lowest: compounds 3 and 4 (each within the scatter of the next); then compounds 2 and 1 (each within the scatter of the next).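

In this assay, the fully saturated open chain 3-carboxy-1-methylpropyl also brings a clear drop, with a 2.7-fold lower number from compound 1 to compound 4 (0.43 log units; beyond the scatter) and a 2.1-fold lower number from compound 2 to compound 4 (0.31 log units; beyond the scatter), so the separation no longer belongs to the carbon-carbon double bond of compound 3 alone. The remaining step is a 1.1-fold higher number from compound 3 to compound 4 (0.03 log units; within the scatter), which leaves those two compounds level. Nothing given here accounts for these differences.

The step from compound 1 changes the chain's size and its methyl branching together, and the compounds shown do not separate the two. Going by these compounds, how a chain ending in a primary amide instead of the carboxylic acid would behave also stays open.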